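Fluoro in place of chloro on an aromatic carbon

The source may report more compounds than this note shows. Statements on the series, on what has been measured and on what is new or still open speak of the compounds shown alone.

compound 1 `O=C(CCCCC(S)CCS)Nc1ccccc1` gives 5.49%
compound 2 `O=C(CCCCC(S)CCS)Nc1ccc(Cl)cc1` gives "not active" (no number reported)

In a functional assay on HO8910 cells (Homo sapiens) for inhibition, read by MTT assay, with a stated time of 24 h, tested at 10 ug/mL (on this read-out higher numbers stand for more inhibition of growth at the one concentration tested and lower numbers for less inhibition of growth), compound 2 stands as "not active" (no number reported) with no single number reported, so it has no exact place on the scale. Among the compounds with values here, compound 1 is the only one of the pair with a number, at 5.49% in the same test.

Compound 3 `O=C(CCCCC(S)CCS)Nc1ccc(F)cc1` has not yet been measured. Its change from compound 2 is fluoro in place of chloro on an aromatic carbon and it amounts to fluoro in place of chloro on an aromatic carbon, para to a large group. The rest of the structure is unchanged.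

Within the data shown here, no measured pair shows what such an exchange does in this assay and so the step expected there is none beyond the scatter, in neither direction. Among the measured compounds shown here, the only guides are compound 1 at 5.49% and compound 2 at "not active" (no number reported) and both lie at the low end of the read-out. A report without a number would fit this expectation too. For compound 3 the estimate is 6% with a range from 0% to 18% expected across repeat measurements.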

Compound 3, percent growth inhibition at one concentration: 6.81%
The estimate for compound 3 lay 0.8 percentage points below the measured number, within the range that was stated.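

In this assay, adding fluoro, para to a large group, brings a number 1.3 percentage points higher from compound 1 to compound 3 (within the scatter) and so leaves the read-out of the shared core at the low end of the scale, where compound 1 already stood. Within the data shown here, this gives the first number for a compound with a halogen at this position, and it shows that fluoro there adds no inhibition of growth that can be told apart from the parent. Compound 2 has no number, so the step from compound 2 to compound 3 cannot be read, and the exchange of chloro for fluoro remains without a measured size; no measurement at hand speaks to the cause of what is seen.

Still open, from the compounds shown here alone, is whether any other group at this position, such as an amine, a carboxylic acid or a methoxy group, would move the number beyond the scatter from compound 1. Also open, going by these compounds, is whether a longer chain in the core of compound 1 would change the read-out, and how these compounds would behave at a concentration other than the single one tested.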